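The source may hold more compounds than are shown below. What is called first, only, known or untested is meant among the compounds shown, and "the series" means these compounds.

Compound 2, `CC(=O)c1cccc(Nc2ccnc(SCC(=O)c3ccc(-c4ccccc4)cc3)n2)c1`, gives 12% in a functional assay on ACHN cells (Homo sapiens) for inhibition, read by sulforhodamine B assay, with a stated time of 48 h, tested at 10 uM; on this read-out lower numbers stand for less inhibition of growth and higher numbers for more inhibition of growth at the one concentration tested. Among the three measured compounds it has the lowest number: compound 1, `CCOC(=O)c1ccc(Nc2ccnc(SCC(=O)c3ccc([N+](=O)[O-])cc3)n2)cc1`, gives 15%, a difference that lies within the scatter, while compound 3, `CC(=O)c1ccc(Nc2ccnc(SCC(=O)c3ccc(-c4ccccc4)cc3)n2)cc1`, gives 26%, and the step of a number 14 percentage points higher from compound 2 to compound 3 (beyond the scatter) is the only one that reaches beyond the scatter.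

Compound 4, `CC(=O)c1cccc(Nc2ccnc(SCC(=O)c3ccc(C(F)(F)F)cc3)n2)c1`, differs from compound 2 in one place: trifluoromethyl in place of phenyl on an aromatic carbon. Among the measured compounds shown here, no measured step touches this part of the molecule; the one step available, from compound 2 to compound 3, concerns the acetyl group on the other side and says nothing about the group para to the ketone. Compound 1, which carries a nitro group at that position together with a different group on the nitrogen, gives a number within the scatter of compound 2, but it is not a single-change comparison. For the measured compounds named here, with no bearing step, no change beyond the scatter is expected in this assay.

Compound 4 is therefore estimated to give 14%, within a range from 2% to 30%. The expected step of a number 2 percentage points higher from compound 2 to compound 4 (within the scatter) is judged to stay within the scatter.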

Compound 4, percent growth inhibition at one concentration: 19%
Estimate against measurement, compound 4: 5 percentage points below; measured number inside the range.
By their numbers in this assay, from the lowest: compounds 2, 1, 4 and 3 (each within the scatter of the next, the first and the last beyond it).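

In this assay, among the compounds shown here, trifluoromethyl in place of phenyl on an aromatic carbon gives a number 7 percentage points higher from compound 2 to compound 4 (within the scatter), the first reading at a position that no earlier step had touched. At this position, therefore, the six-membered aromatic ring of carbon only can give way to a group with no ring and the read-out stays within the scatter, although this rests on a single pair with 3-acetylphenyl held fixed on the nitrogen. Nothing available explains this outcome.

On these data alone, whether an amine, a carboxylic acid or a longer chain at this position would carry the number beyond the scatter remains open. Also open, as far as these compounds go, is how trifluoromethyl would fare with 4-acetylphenyl in place of 3-acetylphenyl, the change that gives a number 14 percentage points higher from compound 2 to compound 3 (beyond the scatter).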